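From 4-methoxybenzyl to 2-methylbenzyl on a shared core

The source may report more compounds than this note shows. Statements on the series, on what has been measured and on what is new or still open speak of the compounds shown alone.

Values in a functional assay on A549 cells (Homo sapiens) for inhibition, read by MTT assay, with a stated time of 72 h (on this read-out lower numbers stand for stronger inhibition and higher numbers for weaker inhibition), stand as follows
compound 1 (`Cc1cccc(CN2CCc3ncn(COCc4ccccc4)c3/C(=C/c3ccccc3)C2=O)c1`) gives 16100 nM
compound 2 (`O=C1/C(=C\c2ccccc2)c2c(ncn2COCc2ccccc2)CCN1Cc1ccc(-c2ccccc2)cc1`) gives 18300 nM
compound 3 (`COc1ccc(CN2CCc3ncn(COCc4ccccc4)c3/C(=C/c3ccccc3)C2=O)cc1`) gives 46800 nM

Of these three, compound 3 stands highest, so it shows the weakest inhibition. Compound 4 (`Cc1ccccc1CN1CCc2ncn(COCc3ccccc3)c2/C(=C/c2ccccc2)C1=O`) is still unmeasured and differs from it by one group (2-methylphenyl in place of 4-methoxyphenyl on a saturated chain carbon bound to an amide-type nitrogen in a ring), with 2-methylphenyl in place of 4-methoxyphenyl. The closest evidence is the swap of 3-methylphenyl for 4-methoxyphenyl (a 2.9-fold higher number from compound 1 to compound 3 (0.46 log units; beyond the scatter)). The swap of phenyl for methoxy points the same way (a 2.6-fold higher number from compound 2 to compound 3 (0.41 log units; beyond the scatter)), while compound 1 and compound 2 sit within the scatter (a 1.1-fold higher number from compound 1 to compound 2 (0.06 log units; within the scatter)). Among the compounds with values here, no 2-methylphenyl compound has a value yet, so a modest fall of similar size is expected in this assay and the estimated step is (a 2.3-fold lower number from compound 3 to compound 4 (0.37 log units; beyond the scatter)). For compound 4 the estimated value is 20000 nM with an expected range of 9000 nM to 45000 nM in this assay.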

Compound 4, half-maximal inhibitory concentration: 25600 nM
For compound 4 the middle estimate is 1.3-fold (0.11 log units) below the measured one; measured number inside the range.
By their numbers in this assay, from the lowest: compounds 1, 2, 4 and 3 (each within the scatter of the next, the first and the last beyond it).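

In this assay, 2-methylphenyl at this place gives a number that lies within the scatter of all three earlier compounds (a 1.8-fold lower number from compound 3 to compound 4 (0.26 log units; within the scatter)) (a 1.4-fold higher number from compound 2 to compound 4 (0.15 log units; within the scatter)) (a 1.6-fold higher number from compound 1 to compound 4 (0.20 log units; within the scatter)). Compound 4 therefore bridges the gap that had set compound 3 apart from compound 1 and compound 2, and moving the methyl group from the 3-methylphenyl of compound 1 to the 2-methylphenyl of compound 4 gives no readable change. Nothing available explains these numbers.

On these data alone, it remains open how an amine or a carboxylic acid on this phenyl ring would read. As far as these compounds go, a longer chain carrying the ring also remains untested here.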